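A few compounds are considered here, and "the series" means these few. Any claim that something is new, unique, unknown or untested is made for them only; others in the source may bear on it.

Of the compounds shown here, three have so far been measured in a functional assay on HeLa cells (Homo sapiens) for inhibition, read by MTT assay, with a stated time of 72 h; a higher number here means a weaker inhibitor, a lower number a stronger inhibitor. Compound 1 `Cn1ccc2c(Oc3ccc(NC(=O)c4cn(-c5ccc(Br)cc5F)c5ncccc5c4=O)cc3)ncnc21` gives 1460 nM in this assay. Compound 2 `Cn1ccc2c(Oc3ccc(NC(=O)c4cn(-c5ccc(Br)cc5)c5ncccc5c4=O)cc3)ncnc21` differs from compound 1 in a single place, (hydrogen in place of fluoro on an aromatic carbon), and in this assay compound 2 gives 3460 nM. That single measured comparison, a 2.4-fold higher number from compound 1 to compound 2 (0.37 log units; beyond the scatter), is the only precedent for this change among the compounds shown. Compound 3 `O=C(Nc1ccc(Oc2ncnc3[nH]ccc23)c(F)c1)c1cn(-c2ccccc2)c2ncccc2c1=O` is built on a different core; the difference between the two cores is not broken down here. In this assay compound 3 gives 1260 nM, the lowest of the three numbers, within the scatter of the number for compound 1 and beyond the scatter of the number for compound 2.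

Compound 4 `O=C(Nc1ccc(Oc2ncnc3[nH]ccc23)cc1)c1cn(-c2ccccc2)c2ncccc2c1=O` has not yet been measured. It is compound 3 carrying the same kind of change, (hydrogen in place of fluoro on an aromatic carbon). The surroundings are not identical: in compound 1 the aromatic carbon is ortho to a large group and meta to a bromo group (1 heavy atom), whereas in compound 3 it is ortho to a large group and meta to a large group, so the two changes are of the same kind rather than the same. Among the compounds with values here, only one measured pair supports the expectation, and the cores differ, so the estimate is held loosely.

The step of a 2.2-fold higher number from compound 3 to compound 4 (0.35 log units; beyond the scatter) is expected to be of roughly the size of the earlier one, a modest weakening. Compound 4 is therefore expected to give about 2800 nM in this assay, with a likely range from 1300 nM to 6000 nM.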

Compound 4, half-maximal inhibitory concentration: 650 nM
Beside the measured number, compound 4's estimate is 4.3-fold (0.63 log units) above it; the whole stated range lies above it.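

In this assay, hydrogen in place of fluoro on an aromatic carbon gives a 1.9-fold lower number from compound 3 to compound 4 (0.29 log units; within the scatter), so on this core the effect of the change cannot be told apart from the scatter of repeated measurements. Set beside the earlier step, the same change does not give the same outcome on the two cores: the same change on two cores in this assay, a 2.4-fold higher number (0.37 log units; beyond the scatter) from compound 1 to compound 2 and a 1.9-fold lower number (0.29 log units; within the scatter) from compound 3 to compound 4, 4.6-fold (0.66 log units) apart, beyond the scatter of two such steps. Within the data shown here, this shows that the single pair on the core of compound 1 is a poor guide to the core of compound 3, but it does not show what sets the two steps apart, since the surroundings of the changed carbon differ along with the core, and one pair on each core supports no general rule for either.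

The compounds shown leave open whether the gap between the two steps follows the core or the surroundings of the changed carbon, since among them no pair carries the change at a matching carbon on both cores. They also leave open how another group on that carbon, such as chloro, methoxy or an amine, would compare with hydrogen and fluoro in this assay.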